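The source may hold more compounds than are shown below. What is called first, only, known or untested is meant among the compounds shown, and "the series" means these compounds.

Measured so far in a functional assay on Bel-7402 cells (Homo sapiens) for cytotoxicity, read by MTT assay, with a stated time of 72 h; on this read-out lower numbers stand for stronger inhibition and higher numbers for weaker inhibition:
- compound 1 `O=C1C=CCC/C1=C\C=C\c1ccccc1`: 4200 nM
- compound 2 `Cc1ccc(/C=C/C=C2\CCC=CC2=O)cc1`: 6300 nM
- compound 3 `O=C1C=CCC/C1=C\C=C\c1ccc(F)cc1`: 1800 nM

Compound 3 holds the lowest number of the three, and its steps to both others lie beyond the scatter. The next compound, compound 4 `O=C1C=CCC/C1=C\C=C\c1ccc(Cl)cc1`, has chloro in place of fluoro on an aromatic carbon, para to a large group: chloro in place of fluoro on an aromatic carbon.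

Among the compounds with values here, no measured compound carries chloro, so the guidance is indirect. Fluoro in place of hydrogen gave a 2.3-fold lower number from compound 1 to compound 3 (0.37 log units; beyond the scatter), a modest step. Fluoro in place of methyl gave a 3.5-fold lower number from compound 2 to compound 3 (0.54 log units; beyond the scatter), also modest. Methyl in place of hydrogen gave a 1.5-fold higher number from compound 1 to compound 2 (0.18 log units; within the scatter), which stays within the scatter. Changes at this spot have therefore been small so far, and nothing shown points to a large one here. In this assay, the expected result is a 1.2-fold higher number from compound 3 to compound 4 (0.09 log units; within the scatter), with no change beyond the scatter expected. The estimated value for compound 4 is 2200 nM, within an expected range of 900 nM to 5000 nM.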

Compound 4, half-maximal inhibitory concentration: 3200 nM
Compound 4: the middle estimate sits 1.5-fold (0.16 log units) below what was measured; low and high end bracket the measured number.
By their numbers in this assay, from the lowest: compounds 3, 4, 1 and 2 (each within the scatter of the next, the first and the last beyond it).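

In this assay chloro on this aromatic carbon cannot be separated from any of the three other groups: fluoro leaving for chloro gives (a 1.8-fold higher number from compound 3 to compound 4 (0.25 log units; within the scatter)), methyl leaving for chloro gives (a 2.0-fold lower number from compound 2 to compound 4 (0.29 log units; within the scatter)), and hydrogen leaving for chloro gives (a 1.3-fold lower number from compound 1 to compound 4 (0.12 log units; within the scatter)). Of the two halogens, only fluoro has a step from hydrogen that lies beyond the scatter, yet fluoro and chloro stay within the scatter of each other, so these numbers do not show the two halogens acting differently here. No measurement at hand explains these results.

The compounds shown leave open what bromo, methoxy, an amine or a carboxylic acid would do on this aromatic carbon. They also leave open whether chloro would give a similar result elsewhere on the ring.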